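This account rests on a few compounds, and the source may have more. Where it says the series, first, only, none or still open, it means among the compounds named here.

Of the compounds shown here, two have so far been measured in an assay for inhibition of Indoleamine 2,3-dioxygenase 1 (Homo sapiens), with stated times of 10 min and 60 min, tested at 100 uM; a higher number here means a stronger effect of the compound at the concentration tested, a lower number a weaker effect. Compound 1 `O=[N+]([O-])c1ccccc1CNc1cc(Br)cc2cn[nH]c12` gives 9%. Compound 2 `Nc1cccc(CNc2cc(C(F)(F)F)cc3[nH]ncc23)c1` gives 55%, the higher of the two numbers, and its gap to compound 1 lies beyond the usual scatter of repeated measurements. Compound 3 `Oc1ccc(CNc2cc(C(F)(F)F)cc3[nH]ncc23)cc1` has not yet been measured in this assay. It differs from compound 2 in a single place: 4-hydroxyphenyl in place of 3-aminophenyl on a saturated chain carbon bound to a nitrogen on an aromatic ring. Within the data shown here, no pair of measured compounds shows how this particular change shifts the read-out, and compound 1 and compound 2 differ in more than one place, so they cannot serve as a guide either. The expectation is therefore a moderate decrease, because compound 2 sits at 55% and the exchanged group keeps the same count of donors and acceptors while moving their kind and position. Compound 3 is expected to give about 40% in this assay, within a range from 15% to 65%. That estimate corresponds to a step of a number 15 percentage points lower from compound 2 to compound 3 (beyond the scatter), a drop just beyond the scatter.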

Compound 3, a percentage reported as inhibition, at one concentration (the size of the read-out at that concentration, not a potency): 81%
Compound 3: middle estimate off by 41 percentage points, on the low side; measured number above the stated range.
By their numbers in this assay, from the lowest: compound 1; then compound 2; then compound 3.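

In this assay, exchanging 3-aminophenyl for 4-hydroxyphenyl on a saturated chain carbon bound to a nitrogen on an aromatic ring is a step of a number 26 percentage points higher from compound 2 to compound 3 (beyond the scatter). This shows that the read-out responds to what this ring carries, even though both groups have the same counts of heavy atoms, hydrogen-bond donors and hydrogen-bond acceptors. The exchange changes both the kind of group on the ring and where it sits, and no information here explains the rise.

The compounds shown do not separate the effect of the oxygen from that of its position on the ring. It also remains open how the read-out would change with a methoxy group or a carboxylic acid in place of the hydroxyl of 4-hydroxyphenyl, and a single-concentration read-out gives no potency for any of these compounds.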